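Straightening the Alkoxy Chain of Compound 1

The compounds below may be only part of what the source reports. "The series", "measured", "known", "first", "only" and "open" are said of these compounds alone.

Compound 1 `CC(C)COc1cc(-c2ccccc2)nc2ccccc12` carries an isobutoxy group on the shared core. In a functional assay on L1210 (1565) cells (Mus musculus) for cytotoxicity (a higher number here means that more compound is needed for the effect, a lower number that less compound is needed), compound 1 gives only a limit, > 10 ug/mL, and not a number; its value sits at the limit of > 10 ug/mL in this assay, at which 1 of the 3 values shown sits. Two relatives bearing a free hydroxyl behave differently: compound 2 `Oc1cc(-c2ccccc2)nc2cc(F)ccc12` gives 0.16 ug/mL and compound 3 `Oc1cc(-c2ccccc2)nc2c(F)cccc12` gives 0.57 ug/mL in this assay. Compound 4 `CCCCOc1cc(-c2ccccc2)nc2ccccc12` is the butoxy counterpart of compound 1; the change is propyl in place of isopropyl on a saturated chain carbon bound to an oxygen on an aromatic ring, the same atoms joined differently. Among the measured compounds shown here, because compound 1 stands at a limit, no measured step shows how such a rearrangement acts. The step that the limit leaves unreadable from compound 1 to compound 4 is expected to stay within the scatter, with compound 4 likely again reported as a limit. Compound 4 is estimated at 15 ug/mL, between 5 ug/mL and 50 ug/mL, in this assay.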

Compound 4, half-maximal effective concentration: > 10 ug/mL
Compound 4 gave a limit, no number; the forecaster's own chance of this, stated with the estimate: 75%; the middle value is on the limit's open side.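

Compound 4, like compound 1, gives only a limit in this assay, so no step between the two can be read: the limit of > 10 ug/mL in this assay, at which 2 of the 4 values shown sit.

The compounds shown leave open whether propyl in place of isopropyl changes the concentration needed at all.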